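Swapping the aryl group on a triazole in a chromene series

A few compounds are considered here, and "the series" means these few. Any claim that something is new, unique, unknown or untested is made for them only; others in the source may bear on it.

Compound 1 `CCOC(=O)C1=Cc2ccccc2OC1(OCc1cn(-c2ccc(F)cc2)nn1)C(F)(F)F`: 9100 nM
Compound 2 `CCOC(=O)C1=Cc2ccccc2OC1(OCc1cc(-c2ccc(OC)cc2)no1)C(F)(F)F`: > 150000 nM

Within the data shown here, in a functional assay on MCF7 cells (Homo sapiens) for inhibition, read by MTT assay, with a stated time of 24 h (on this read-out lower numbers stand for stronger inhibition and higher numbers for weaker inhibition), compound 1 gives 9100 nM, the only number recorded here. Compound 2 reaches only a limit of the assay, > 150000 nM, as the limit of > 150000 nM in this assay, at which 1 of the 2 values shown sits, records. Compound 3 `CCOC(=O)C1=Cc2ccccc2OC1(OCc1cn(-c2cccc(C(F)(F)F)c2)nn1)C(F)(F)F` has not yet been measured. It differs from compound 1 by 3-(trifluoromethyl)phenyl in place of 4-fluorophenyl on an aromatic nitrogen. Among the measured compounds shown here, no measured pair tells how this kind of exchange shifts the read-out, so the expectation rests on compound 1 alone. A change from compound 1 to compound 3 of about a 1.1-fold lower number from compound 1 to compound 3 (0.06 log units; within the scatter) is expected, within the ordinary scatter. Compound 3 is therefore estimated at 8000 nM, plausibly between 2500 nM and 30000 nM.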

Compound 3, half-maximal inhibitory concentration: > 150000 nM
Compound 3 ended at the assay's limit; the forecaster's own chance of this, stated with the estimate: 15%; at least 18-fold (1.27 log units) between middle value and limit.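

In this assay, the group on the aromatic nitrogen proves decisive, as 3-(trifluoromethyl)phenyl in place of 4-fluorophenyl gives an at least 16-fold higher number from compound 1 to compound 3 (1.21 log units; beyond the scatter). For compound 3, > 150000 nM is a limit of the assay and not a number. One exchange at this position is thus enough to reach the end of the readable range: the limit of > 150000 nM in this assay, at which 2 of the 3 values shown sit.

The compounds shown leave open whether the change in substituent or the change in its place on the phenyl ring matters more, which 3-fluorophenyl or 4-(trifluoromethyl)phenyl would help to separate. They also leave open how a phenyl ring carrying an amine or a carboxylic acid would behave.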